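Methyl added to the shared core of compound 2

A few compounds are considered here, and "the series" means these few. Any claim that something is new, unique, unknown or untested is made for them only; others in the source may bear on it.

Compound 1 `CNc1nncc2cncn12` and compound 2 `Sc1nncc2cncn12` share one core and differ at a single aromatic carbon. In a functional assay for inhibition, with Homo sapiens as the target (a higher number here means a weaker inhibitor, a lower number a stronger inhibitor), compound 1 gives only a limit, > 48000 nM. In this assay compound 2 likewise gives only a limit, > 48000 nM. The step that the two limits leave unreadable from compound 1 to compound 2 is therefore not readable; both results fall under (the limit of > 48000 nM in this assay, at which 2 of the 2 values shown sit). Compound 3 `Cc1ncn2c(S)nncc12` differs from compound 2 by methyl in place of hydrogen on an aromatic carbon. Going by the values given here, no measured step covers this change, and the only step in the set gives no size at all, so nothing in the numbers points to a direction. Since compound 2 stands at a limit, the expected step that the limit leaves unreadable from compound 2 to compound 3 cannot be told apart from none beyond the scatter, and a further limit is the likely outcome. Compound 3 is estimated at 60000 nM, within a range of 20000 nM to 200000 nM.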

Compound 3, half-maximal inhibitory concentration: > 48000 nM
Compound 3 gave a limit, no number; the forecaster's own chance of this, stated with the estimate: 80%; the middle value does not contradict the limit.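

Compound 3, like compound 2, gives only a limit in this assay, so no step between them can be read: the limit of > 48000 nM in this assay, at which 3 of the 3 values shown sit.

The compounds shown leave open whether methyl in place of hydrogen on an aromatic carbon changes inhibition at all, with no compound here carrying a number in this assay.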